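Swapping 4-Methoxybenzyl for Cyclopentyl on the Amide

This account rests on a few compounds, and the source may have more. Where it says the series, first, only, none or still open, it means among the compounds named here.

Going by the values given here, in a functional assay on A549 cells (Homo sapiens) for inhibition, read by sulforhodamine B assay, with a stated time of 72 h (a higher number here means a weaker inhibitor, a lower number a stronger inhibitor), compound 2 (`COc1ccc(CNC(=O)c2c(N)sc(-c3ccc(Cl)cc3)c2-c2ccc(Cl)cc2)cc1`) gives 18200 nM, the higher of the two numbers measured so far. Compound 1 (`Nc1sc(-c2ccc(Cl)cc2)c(-c2ccc(Cl)cc2)c1C(=O)N1CCCC1`) gives 890 nM. Compound 3 (`Nc1sc(-c2ccc(Cl)cc2)c(-c2ccc(Cl)cc2)c1C(=O)NC1CCCC1`) carries cyclopentyl in place of 4-methoxybenzyl on an amide-type nitrogen. Among the compounds with values here, only one measured step bears on this change, and it does so indirectly: a 20-fold higher number from compound 1 to compound 2 (1.31 log units; beyond the scatter), a large step in which (4-methoxybenzyl)amino replaces pyrrolidin-1-yl on a carbonyl carbon. Compound 3 also loses the 4-methoxybenzyl but keeps the amide hydrogen, a combination not yet measured. A sizeable move to a lower number is therefore expected in this assay, probably only part of the way back to compound 1. The expected change is a 5.2-fold lower number from compound 2 to compound 3 (0.72 log units; beyond the scatter). For compound 3, the estimated value is 3500 nM, with an expected range of 800 nM to 14000 nM.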

Compound 3, half-maximal inhibitory concentration: 6790 nM
Estimate against measurement, compound 3: 1.9-fold (0.29 log units) below; low and high end bracket the measured number.
By their numbers in this assay, from the lowest: compound 1; then compound 3; then compound 2.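

In this assay, the cyclopentyl group on the amide-type nitrogen gives a 2.7-fold lower number from compound 2 to compound 3 (0.43 log units; beyond the scatter), so removing 4-methoxybenzyl recovers only part of the earlier loss. The comparison with the tertiary amide gives a 7.6-fold higher number from compound 1 to compound 3 (0.88 log units; beyond the scatter), showing that a substantial gap remains even with an all-carbon ring in place of 4-methoxybenzyl, and that compound 1 stays at the lowest number of the three. No evidence accompanying these numbers accounts for either step.

As far as these compounds go, whether the gap to compound 1 follows from the amide hydrogen or from the particular ring on the nitrogen remains open, since compound 3 differs from compound 1 in both respects. From the compounds shown here alone, how a benzyl or cyclohexyl group on the same nitrogen would read, and whether either would fall closer to compound 1, also remains open.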